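Aryl for alkyl on the five-membered ring

This account rests on a few compounds, and the source may have more. Where it says the series, first, only, none or still open, it means among the compounds named here.

Of the compounds shown here, three of a shared core have been tested so far. Compound 1 `CCCc1cc(-c2cn([C@H]3C[C@H](OC(C)=O)[C@@H](COC(C)=O)O3)c(=O)[nH]c2=O)on1` gives 89.1% in a functional assay on NUGC-3 cells (Homo sapiens) for cytotoxicity, read by sulforhodamine B assay, tested at 10 uM; a higher number here means more inhibition at the concentration tested (going by the name of the read-out), a lower number less inhibition. Compound 2 `CCCCCc1cc(-c2cn([C@H]3C[C@H](OC(C)=O)[C@@H](COC(C)=O)O3)c(=O)[nH]c2=O)on1` gives 91.9% in this assay, and compound 3 `CC(=O)OC[C@H]1O[C@@H](n2cc(-c3cn(Cc4ccc(C(C)C)cc4)nn3)c(=O)[nH]c2=O)C[C@@H]1OC(C)=O` gives 95.4% in this assay. Compound 2 stands second highest of the three numbers; its nearest neighbour is compound 1 and its furthest is compound 3, and both gaps lie within the scatter, so the three cannot be ordered.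

The unmeasured compound 4 `CC(=O)OC[C@H]1O[C@@H](n2cc(-c3cc(-c4ccc(C(C)C)cc4)no3)c(=O)[nH]c2=O)C[C@@H]1OC(C)=O` differs from compound 2 in one place: 4-isopropylphenyl in place of pentyl on an aromatic carbon. Among the compounds with values here, the only measured step that touches this position is the one from compound 1 to compound 2, where an ethyl replaces a hydrogen on the chain and the number moves by a number 2.8 percentage points higher from compound 1 to compound 2 (within the scatter), within the scatter. Compound 3 carries the same 4-isopropylphenyl group, though on a different ring, and its value and that of compound 2 lie within the scatter of each other. Within the data shown here, no measured step shows a change of more than a few points at this concentration, so compound 4 is expected to move by about a number 0.1 percentage points higher from compound 2 to compound 4 (within the scatter), that is, nothing beyond the scatter. Compound 4 is therefore estimated at 92% in this assay, between 82% and 98%.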

Compound 4, a percentage reported as inhibition, at one concentration (the size of the read-out at that concentration, not a potency): 56.4%
Compound 4: middle estimate off by 35.6 percentage points, on the high side; measured number below the stated range.
By their numbers in this assay, from the lowest: compound 4; then compounds 1, 2 and 3 (each within the scatter of the next).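

In this assay, this position, on an aromatic carbon of the five-membered aromatic ring with 1 nitrogen and 1 oxygen, turns out to respond strongly to the group it carries: 4-isopropylphenyl in place of pentyl gives a number 35.5 percentage points lower from compound 2 to compound 4 (beyond the scatter) and 4-isopropylphenyl in place of propyl gives a number 32.7 percentage points lower from compound 1 to compound 4 (beyond the scatter) in the same read-out. The earlier step at this position, which stayed among the alkyl chains, gave only a number 2.8 percentage points higher from compound 1 to compound 2 (within the scatter) and so showed that propyl and pentyl cannot be told apart here, whereas the change from a chain to a substituted six-membered aromatic ring of carbon only has a large effect in both new steps. Nothing at hand gives a measured reason for this drop.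

The compounds shown leave open whether the drop goes with the phenyl ring itself or with its isopropyl group, which an unsubstituted phenyl or a 4-methoxyphenyl at this position would help to separate. They also leave open how a benzyl group or a longer chain such as octyl would read at the same carbon.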